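Amine Variation on the Propoxy Chain: Series Notes

The source may hold more compounds than are shown below. What is called first, only, known or untested is meant among the compounds shown, and "the series" means these compounds.

Measured compounds:
compound 1, `COc1cc2c(Nc3ccc(C#N)cc3)ncnc2cc1OCCCN(C)C`, > 100000 nM
compound 2, `CCN(CC)CCCOc1cc2ncnc(Nc3ccc(C#N)cc3)c2cc1OC`, 59400 nM

In a functional assay on HepG2 cells (Homo sapiens) for antiproliferative activity, read by MTT assay, with a stated time of 72 h (on this read-out lower numbers stand for stronger inhibition and higher numbers for weaker inhibition), compound 1 gives > 100000 nM, which is a limit of the assay and not a number (the limit of > 100000 nM in this assay, at which 1 of the 2 values shown sits). In this assay compound 2 gives 59400 nM; this is the only number shown. Going by the values given here, the one measured step is an at least 1.6-fold lower number from compound 1 to compound 2 (0.22 log units; that floor lies within the scatter), and its floor lies within the scatter.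

Compound 3, `COc1cc2c(Nc3ccc(C#N)cc3)ncnc2cc1OCCCN(C)Cc1ccccc1`, differs from compound 2 as follows: benzyl(methyl)amino in place of diethylamino on a saturated chain carbon, three bonds along the chain from an oxygen on an aromatic ring. Among the compounds with values here, only the step from compound 1 to compound 2 bears on this change, both enlarging the amine on the chain, and that step was at best small. A modest lowering of the number in this assay is therefore expected, with no firm claim beyond the scatter.

Compound 3 is expected to give 30000 nM in this assay, within 8000 nM to 100000 nM. The expected step is a 2.0-fold lower number from compound 2 to compound 3 (0.30 log units; within the scatter).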

Compound 3, half-maximal inhibitory concentration: > 100000 nM
Compound 3: a limit, no number; the forecaster's own chance of this, stated with the estimate: 25%; at least 3.3-fold (0.52 log units) between middle value and limit.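

Benzyl(methyl)amino in place of diethylamino on the saturated chain carbon brings an at least 1.6-fold higher number from compound 2 to compound 3 (0.22 log units; that floor lies within the scatter), so the larger amine with its six-membered aromatic ring shows no lowering of the number in this assay. Compound 3 gives > 100000 nM, which is a limit and not a number. Compound 2 therefore stays the only compound here with a number, and the step from compound 1 to compound 3 cannot be read, because both values are limits: the limit of > 100000 nM in this assay, at which 2 of the 3 values shown sit.

Going by these compounds, whether the amine's size or the aromatic ring decides the outcome stays open, and dipropylamino or a benzyl group carrying a carboxylic acid could help separate the two. Also open, on these data alone, is whether diethylamino on a longer chain would give a number clearly apart from compound 2.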